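The source may hold more compounds than are shown below. What is called first, only, known or untested is meant among the compounds shown, and "the series" means these compounds.

Three compounds built on the same sulfamate-bearing core have been examined in an assay on HEK293 cells for inhibition of Steryl-sulfatase (Homo sapiens), tested at 1 uM; a lower number here means a weaker effect, a higher number a stronger effect of the compound at the concentration tested. Compound 1 `CCN(Cc1ccc(Br)cc1)c1cccc(C(=O)N2CCc3ccc(OS(N)(=O)=O)cc3C2)c1` gives 84.5% in this assay. Compound 2 `NS(=O)(=O)Oc1ccc2c(c1)CN(C(=O)c1ccc(N(Cc3ccccc3)Cc3ccco3)cc1)CC2` gives 98.2%, and compound 3 `CCN(Cc1ccncc1)c1ccc(C(=O)N2CCc3ccc(OS(N)(=O)=O)cc3C2)cc1` gives 86.6%. Among these three numbers compound 1 stands lowest; its gap to compound 3 lies within the scatter of repeated measurements, whereas its gap to compound 2 lies beyond it. Compound 4 `CCN(Cc1ccc(F)cc1)c1cccc(C(=O)N2CCc3ccc(OS(N)(=O)=O)cc3C2)c1` has not yet been measured. It differs from compound 1 in one place: fluoro in place of bromo on an aromatic carbon. For the measured compounds named here, no step between two measured compounds touches this position, so nothing measured here says how large the effect of this exchange should be. Given that compound 1 already gives 84.5% and the change is limited to one substituent on that aromatic carbon, the step of a number 3.5 percentage points lower from compound 1 to compound 4 (within the scatter) is expected to stay within the scatter, with no clear direction. For compound 4 the estimated inhibition is 81%, with a range from 66% to 92%.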

Compound 4, a percentage reported as inhibition, at one concentration (the size of the read-out at that concentration, not a potency): 66.5%
The estimate for compound 4 lay 14.5 percentage points above the measured number; the measured number falls inside the stated range.
By their numbers in this assay, from the lowest: compound 4; then compounds 1 and 3 (each within the scatter of the next); then compound 2.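

In this assay the exchange of bromo for fluoro gives a number 18 percentage points lower from compound 1 to compound 4 (beyond the scatter), which shows that this position on the aromatic ring is not indifferent to which substituent it carries. Both groups count one heavy atom, with no hydrogen-bond donors or acceptors and no net charge, so these counts do not separate compound 1 from compound 4. Nothing available gives a reason for this step.

On these data alone, whether a chloro, methyl or methoxy group on the same carbon would give a number closer to compound 1 or to compound 4 remains open, as does the result for a plain benzyl group with no substituent there. The compounds shown also leave open whether the same exchange would give a step of similar size elsewhere in the series.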